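From hexyl to hept-1-yn-1-yl on the shared core

The source may hold more compounds than are shown below. What is called first, only, known or untested is meant among the compounds shown, and "the series" means these compounds.

In a functional assay on HEL cells (Homo sapiens) (a higher number here means that more compound is tolerated, a lower number that less compound is tolerated), compound 2 `CCCCCCc1cc2cn(COCCO)c(=O)nc2o1` gives > 200000 nM, which is a limit and not a number. This places compound 2 at the limit of > 200000 nM in this assay, at which 1 of the 2 values shown sits. Compound 1 `CCCCCCCCC#Cc1cc2cn(COCCO)c(=O)nc2o1`, whose longer chain holds a triple bond, gives a measured 42000 nM.

Compound 3 `CCCCCC#Cc1cc2cn(COCCO)c(=O)nc2o1` carries hept-1-yn-1-yl in place of hexyl on an aromatic carbon. For the measured compounds named here, no measured step isolates this change, so the only guide is the pair of values from compound 1 and compound 2. Compound 3 shares the triple bond of compound 1 but has a shorter chain, so it is expected to fall between the two in this assay, possibly still at the limit. The expected change is a modest downward one, an at least 1.8-fold lower number from compound 2 to compound 3 (0.25 log units; that floor lies within the scatter). For compound 3 the estimated value is 110000 nM, with an expected range of 45000 nM to 200000 nM.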

Compound 3, half-maximal cytotoxic concentration: > 50000 nM
Compound 3: no number, only a limit; the forecaster's own chance of this, stated with the estimate: 40%; the middle value is on the limit's open side.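

In this assay compound 3 gives no number, only a limit, so hept-1-yn-1-yl at this position is not yet placed on the scale: the limit of > 50000 nM in this assay, at which 1 of the 3 values shown sits. The step from hexyl to hept-1-yn-1-yl cannot be read, as compound 2 and compound 3 both stand as limits, so this change has no measured size or direction. Within the chains carrying a triple bond, hydrogen in place of propyl on a saturated chain carbon gives an at least 1.1-fold higher number from compound 1 to compound 3 (0.07 log units; that floor lies within the scatter), so the shorter chain is not shown to differ from the longer one.

A measured number for compound 3 would be needed to show whether shortening this chain matters at all. Also open, from the compounds shown here alone, is how a saturated heptyl chain, or an amine at the chain end, would compare on the shared core.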